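Ethylating the sulfonamide nitrogen of compound 2

The source may hold more compounds than are shown below. What is called first, only, known or untested is meant among the compounds shown, and "the series" means these compounds.

The two measured compounds share one core and differ only at the chain on the ring nitrogen. Compound 1 `CS(=O)(=O)NNc1nonc1/C(=N/O)Nc1ccc(F)c(Br)c1` is reported in an assay on HeLa cells for inhibition of Indoleamine 2,3-dioxygenase 1 (Homo sapiens), read by spectrophotometry, with a stated time of 24 h (on this read-out higher numbers stand for an effect only at larger amounts of compound and lower numbers for an effect already at smaller amounts), only as a limit, > 800 nM, with no number behind it. Compound 2 `NS(=O)(=O)CCNc1nonc1/C(=N/O)Nc1ccc(F)c(Br)c1` gives 11 nM in this assay. Among the compounds with values here, the step of an at least 72-fold lower number from compound 1 to compound 2 (1.86 log units; beyond the scatter) is therefore the one measured change in this set, and it rests on a limit on one side (the limit of > 800 nM in this assay, at which 1 of the 2 values shown sits). Within the data shown here, compound 2 thus stands as the sole compound with a proper number in this assay.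

Compound 3 `CCNS(=O)(=O)CCNc1nonc1/C(=N/O)Nc1ccc(F)c(Br)c1` keeps the whole of compound 2 and adds (ethyl in place of hydrogen on a sulfonamide nitrogen). Among the measured compounds shown here, no measured step touches this sulfonamide nitrogen; the single step from compound 1 to compound 2 changed the whole chain rather than a substituent on its end. For the measured compounds named here, with no comparable step available, the account expects compound 3 to stay close to compound 2, with the step of a 1.8-fold higher number from compound 2 to compound 3 (0.26 log units; within the scatter) expected to lie within or only slightly beyond the scatter. For compound 3 the estimate in this assay is 20 nM, between 6 nM and 70 nM.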

Compound 3, half-maximal effective concentration: 41 nM
For compound 3 the middle estimate is 2.1-fold (0.31 log units) below the measured one; measured number inside the range.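

In this assay, within the data shown here, this is the first step that changes only the end of the chain, leaving the rest of the molecule untouched, and putting ethyl on the sulfonamide nitrogen has a real but modest cost: a 3.7-fold higher number from compound 2 to compound 3 (0.57 log units; beyond the scatter). The nitrogen therefore does not have to stay unsubstituted for the number to remain low, and the ethylated chain keeps most of the advantage over the methanesulfonamido group of compound 1, with an at least 19-fold lower number from compound 1 to compound 3 (1.29 log units; beyond the scatter). Like the earlier step from that compound, this comparison gives only a minimum size and not a full measure of the difference, as one side of it is a limit: the limit of > 800 nM in this assay, at which 1 of the 3 values shown sits.

With ethyl as the only substituent shown on this nitrogen, one step cannot say whether the cost grows with the size of the group, which a methyl, a propyl or a cyclopropyl there would begin to test, and nothing shown gives a cause for the cost. As far as these compounds go, it also remains open how a carboxylic acid in place of the sulfamoyl group, or a longer chain in place of the ethyl linker, would read in this assay.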